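From piperidin-1-yl to 2-aminoethyl on compound 3

A few compounds are considered here, and "the series" means these few. Any claim that something is new, unique, unknown or untested is made for them only; others in the source may bear on it.

Compound 3 `O=[N+]([O-])c1ccc(/C=C/c2nc(NCCN3CCCCC3)c3ccccc3n2)cc1` gives (> 100000 nM) in a functional assay on L02 cells (Homo sapiens) for cytotoxicity, read by MTT assay, with stated times of 48 h and 4 h (on this read-out higher numbers stand for weaker inhibition and lower numbers for stronger inhibition), and this is a limit of the assay, not a number. Among the measured compounds shown here, it is the only compound standing at that limit (the limit of > 100000 nM in this assay, at which 1 of the 3 values shown sits) so far. In this assay compound 1 `COc1ccc(/C=C/c2nc(NCCN3CCCCC3)c3ccccc3n2)cc1OC` gives 19800 nM as a number, and compound 2 `CC(C)N(CCNc1nc(/C=C/c2ccc([N+](=O)[O-])cc2)nc2ccccc12)C(C)C` gives 8960 nM as a number.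

The next change leads to compound 4 `NCCCCNc1nc(/C=C/c2ccc([N+](=O)[O-])cc2)nc2ccccc12` (2-aminoethyl in place of piperidin-1-yl on a saturated chain carbon, two bonds along the chain from a nitrogen on an aromatic ring) with 2-aminoethyl in place of piperidin-1-yl on a saturated chain carbon, two bonds along the chain from a nitrogen on an aromatic ring.

For the measured compounds named here, two measured steps bear on it. The large one, at the same place, is an at least 11-fold higher number from compound 2 to compound 3 (1.04 log units; beyond the scatter) and shows that this end alone can shift the read-out. The other, at least modest and at the far end, is an at least 5.0-fold higher number from compound 1 to compound 3 (0.70 log units; beyond the scatter) and does not touch this place. Compound 4 keeps the 4-nitrophenyl of compound 2 (8960 nM) so a move to a lower number is expected. The expected step in this assay is an at least 4.5-fold lower number from compound 3 to compound 4 (0.65 log units; beyond the scatter) and a reading at the limit stays possible. For compound 4 the estimate is 22000 nM (expected range 6000 nM to 80000 nM).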

Compound 4, half-maximal inhibitory concentration: 7460 nM
Beside the measured number, compound 4's estimate is 2.9-fold (0.47 log units) above it; low and high end bracket the measured number.
By their numbers in this assay, from the lowest: compounds 4 and 2 (each within the scatter of the next); then compound 1. At a limit, above all of these: compound 3.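

In this assay the chain end alone moves the read-out a second time: an at least 13-fold lower number from compound 3 to compound 4 (1.12 log units; beyond the scatter) follows from 4-aminobutyl in place of 2-(piperidin-1-yl)ethyl. The reading of compound 3 is a limit of the assay, not a number: the limit of > 100000 nM in this assay, at which 1 of the 4 values shown sits. Among the compounds carrying 4-nitrophenyl, only the piperidin-1-yl end sits apart, while the two open-chain ends read alike, with a 1.2-fold lower number from compound 2 to compound 4 (0.08 log units; within the scatter) lying within the scatter.

Open, as far as these compounds go, is whether a morpholine, a carboxylic acid or a longer chain ending in an amine at this place would read like compound 4 or like compound 3. Also open, from the compounds shown here alone, is how the 3,4-dimethoxyphenyl of compound 1 would read with the 4-aminobutyl end, and the full size of the piperidin-1-yl step stays unfixed while compound 3 has only a limit.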